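The source may report more compounds than this note shows. Statements on the series, on what has been measured and on what is new or still open speak of the compounds shown alone.

The measured compounds:
compound 1, `COc1ccc([N+](=O)[O-])cc1CSc1nc2cc(NC(=O)NC(C)(C)C)ccc2n1C1CC1`, giving 79 nM in an assay on isolated protein for inhibition of Gonadotropin-releasing hormone receptor (Homo sapiens); a higher number here means a weaker inhibitor, a lower number a stronger inhibitor
compound 2, `CCCCCn1c(SCc2cc([N+](=O)[O-])ccc2OC)nc2cc(NC(=O)NC(C)(C)C)ccc21`, giving 210 nM in this assay
compound 3, `COc1ccc([N+](=O)[O-])cc1CSc1nc2cc(NC(=O)NC(C)(C)C)ccc2n1Cc1cccnc1`, giving 33 nM in this assay

Compound 3 holds the lowest number of the three, and both steps that lead to it lie beyond the scatter: a 2.4-fold lower number from compound 1 to compound 3 (0.38 log units; beyond the scatter) and a 6.4-fold lower number from compound 2 to compound 3 (0.80 log units; beyond the scatter). Compound 4, `COc1ccc([N+](=O)[O-])cc1CSc1nc2cc(NC(=O)NC(C)(C)C)ccc2n1C(C)C`, has not yet been measured. It differs from compound 3 in one place: isopropyl in place of (pyridin-3-yl)methyl on an aromatic nitrogen. Two measured steps change the group on this same aromatic nitrogen. One is a 2.7-fold higher number from compound 1 to compound 2 (0.42 log units; beyond the scatter), where a longer chain gave a weaker inhibitor; the other is a 2.4-fold lower number from compound 1 to compound 3 (0.38 log units; beyond the scatter), where the ring-bearing group gave a stronger one. Isopropyl is small and has no ring, so it stands closer to cyclopropyl than to either of the other groups, and compound 4 is therefore expected to land near compound 1, a modest step upward from compound 3, a 2.7-fold higher number from compound 3 to compound 4 (0.44 log units; beyond the scatter). The estimate for compound 4 in this assay is 90 nM, with a range from 40 nM to 200 nM.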

Compound 4, half-maximal inhibitory concentration: 62 nM
The estimate for compound 4 lay 1.5-fold (0.16 log units) above the measured number; measured number inside the range.
By their numbers in this assay, from the lowest: compounds 3, 4 and 1 (each within the scatter of the next, the first and the last beyond it); then compound 2.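

In this assay, isopropyl on this aromatic nitrogen cannot be told apart from the much larger (pyridin-3-yl)methyl (a 1.9-fold higher number from compound 3 to compound 4 (0.27 log units; within the scatter)) or from cyclopropyl (a 1.3-fold lower number from compound 1 to compound 4 (0.11 log units; within the scatter)), although those two groups do differ from each other beyond the scatter. A ring on this position is therefore not required for a number in this range, whereas pentyl stands clearly apart from isopropyl (a 3.4-fold lower number from compound 2 to compound 4 (0.53 log units; beyond the scatter)). No measurement offered here explains these differences.

A benzyl group would test whether the ring nitrogen of (pyridin-3-yl)methyl matters or whether the carbon ring alone would serve. A propyl or butyl chain would show how much length this position accepts before the number rises to that of the pentyl compound.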